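Removing the Chloro Group from a Weak Growth Inhibitor

A few compounds are considered here, and "the series" means these few. Any claim that something is new, unique, unknown or untested is made for them only; others in the source may bear on it.

Of the compounds shown here, two have been measured in a functional assay on MOLT-4 cells (Homo sapiens) for antiproliferative activity; on this read-out lower numbers stand for stronger inhibition of growth and higher numbers for weaker inhibition of growth. Compound 1 `COc1ccc(-n2cc(-c3ccc(Cl)cc3)[nH]c2=S)cc1Cl` gives 39800 nM in this assay. Compound 2 `COc1cc(-n2cc(-c3ccc(Cl)cc3)[nH]c2=O)cc(OC)c1OC` is reported in this assay only as a limit, > 100000 nM, not as a number. On the numbers shown, compound 2 therefore stands at the limit of > 100000 nM in this assay, at which 1 of the 2 values shown sits. Compound 3 `COc1cc(-n2cc(-c3ccccc3)[nH]c2=O)cc(OC)c1OC` has not yet been measured in this assay. It differs from compound 2 in one place: hydrogen in place of chloro on an aromatic carbon. Going by the values given here, no measured pair of neighbouring compounds shows what this change does here, so its effect in this assay is open. The expected step is a number no higher from compound 2 to compound 3 (the limit leaves the size open), most likely none beyond the scatter, because compound 2 already gives > 100000 nM in this assay. Compound 3 is expected to give about 100000 nM in this assay, within a range from 40000 nM to 300000 nM, with a good chance that only a limit is reported again.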

Compound 3, concentration for 50% growth inhibition: > 100000 nM
Compound 3: a limit, no number (the forecaster's own chance of this, stated with the estimate: 70%); the middle value lies on the limit itself.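

Going by these compounds alone, compound 2 and compound 3 are both reported in this assay only as limits, not as numbers, so no step between them can be read. The compounds shown leave open whether hydrogen in place of chloro changes growth inhibition at all.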